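Extending a ketone chain into a methoxyphenyl-ethenyl arm

The source may report more compounds than this note shows. Statements on the series, on what has been measured and on what is new or still open speak of the compounds shown alone.

Measured so far:
- compound 1 `CCCCCC(=O)c1ccc(OCCCN2CCN(CCCC)CC2)cc1`: 7590 nM
- compound 2 `CCOC(=O)N1CCN(CCCOc2ccc(C(=O)CC(C)C)cc2)CC1`: 69200 nM

Both numbers come from an assay on isolated protein for binding affinity to histamine H2 receptor (Homo sapiens); on this read-out lower numbers stand for stronger inhibition and higher numbers for weaker inhibition. Compound 2 gives the higher of the two numbers and so binds more weakly than compound 1; the two compounds differ in more than one place, so the gap between them is all that can be read. Compound 3 `CCOC(=O)N1CCN(CCCOc2ccc(C(=O)/C=C/c3ccc(OC)cc3)cc2)CC1` is not yet measured. It differs from compound 2 in one place: 2-(4-methoxyphenyl)ethenyl in place of isobutyl on a carbonyl carbon. For the measured compounds named here, no measured pair shows this kind of change, so the size of the step is uncertain. The expectation for the step from compound 2 to compound 3 in this assay is a modest move toward a lower number, a 2.3-fold lower number from compound 2 to compound 3 (0.36 log units; beyond the scatter), though a result within the scatter would not surprise. For compound 3 the estimated inhibition constant is 30000 nM, with a plausible range from 8000 nM to 150000 nM.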

Compound 3, inhibition constant: 6760 nM
For compound 3 the middle estimate is 4.4-fold (0.65 log units) above the measured one; measured number outside the range, below it.
By their numbers in this assay, from the lowest: compounds 3 and 1 (each within the scatter of the next); then compound 2.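

In this assay, for the compounds shown here, 2-(4-methoxyphenyl)ethenyl in place of isobutyl on a carbonyl carbon gives a 10-fold lower number from compound 2 to compound 3 (1.01 log units; beyond the scatter), a large step and the first change at a single place in these compounds. It shows that the group on this carbonyl carbon can strongly shift the measured binding, which the gap between compound 1 and compound 2 could not show, as those two differ in more than one place. The entering group adds a six-membered aromatic ring, a double bond outside aromatic rings and a hydrogen-bond acceptor at once, and no independent evidence accounts for the step or singles out one of these parts.

Open, from the compounds shown here alone, is whether a plain phenyl ring, without the methoxy group, would give a similar number, and whether a saturated two-carbon link would serve as well as the double bond. Going by these compounds, it is also open whether the same swap would give a step of similar size on the core of compound 1.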